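Replacing the sulfur-linked ring of compound 3 by a piperazine

The source may hold more compounds than are shown below. What is called first, only, known or untested is meant among the compounds shown, and "the series" means these compounds.

Compound 3 `Cn1c(-c2ccc(NC(=O)CSC3=NCCS3)cc2)nc(-c2ccccc2)c1-c1ccccc1` gives 41.8% in a functional assay on MCF7 cells (Homo sapiens) for cytotoxicity, read by MTT assay, with a stated time of 24 h, tested at 16 ug/mL (on this read-out higher numbers stand for a stronger effect at the one concentration tested and lower numbers for a weaker effect), the lowest of the three numbers. Compound 1 `Cn1c(-c2ccc(NC(=O)CSc3nc4ccccc4o3)cc2)nc(-c2ccccc2)c1-c1ccccc1` gives 56% and compound 2 `Cc1nnc(SCC(=O)Nc2ccc(-c3nc(-c4ccccc4)c(-c4ccccc4)n3C)cc2)s1` gives 74.9% in this assay. The measured steps were a number 18.9 percentage points higher from compound 1 to compound 2 (beyond the scatter), a number 14.2 percentage points lower from compound 1 to compound 3 (beyond the scatter) and a number 33.1 percentage points lower from compound 2 to compound 3 (beyond the scatter); each of them swaps only the ring on the sulfur. Among the measured compounds shown here, compound 4 `CN(C)/C=C/N1CCN(CC(=O)Nc2ccc(-c3nc(-c4ccccc4)c(-c4ccccc4)n3C)cc2)CC1` instead carries a group of 11 heavy atoms (8 carbon, 3 nitrogen; one six-membered non-aromatic ring with 2 hetero atoms) in place of a group of 6 heavy atoms (3 carbon, 1 nitrogen, 2 sulfur; one five-membered non-aromatic ring with 2 hetero atoms), on a saturated chain carbon bound to a carbonyl carbon, so the sulfur itself is gone and no measured step touches this kind of change. The three measured rings moved the number both ways by modest to large amounts, so compound 4 is expected to lie near the middle of the known range, with a number 8.2 percentage points higher from compound 3 to compound 4 (within the scatter) as the estimated step. Compound 4 is therefore estimated at 50%, within 25% to 75%.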

Compound 4, a percentage reported as activity, at one concentration (the size of the read-out at that concentration, not a potency): 19.4%
Estimate against measurement, compound 4: 30.6 percentage points above; the whole stated range lies above it.
By their numbers in this assay, from the lowest: compound 4; then compound 3; then compound 1; then compound 2.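

In this assay, 4-(2-(dimethylamino)ethenyl)piperazin-1-yl on the saturated chain carbon bound to a carbonyl carbon gives a lower number than each sulfur-linked group, with a number 22.4 percentage points lower from compound 3 to compound 4 (beyond the scatter), a number 36.6 percentage points lower from compound 1 to compound 4 (beyond the scatter) and a number 55.5 percentage points lower from compound 2 to compound 4 (beyond the scatter). Compound 4 therefore lies lowest of the four, and this change lowers the number further than any exchange of the ring on the sulfur. No available evidence explains this drop. From the compounds shown here alone, it remains open whether the drop belongs to the piperazine ring or to its 2-(dimethylamino)ethenyl group. An unsubstituted piperazine or a morpholine at this place would separate the two.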